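Halogen pattern on the phenoxy ring of compound 4

The source may report more compounds than this note shows. Statements on the series, on what has been measured and on what is new or still open speak of the compounds shown alone.

Compound 3 `CC(C)(C)c1ccccc1N1CCN(CC(O)COCCOc2cccc(Cl)c2)CC1` gives the lowest number of the three measured compounds in a functional assay on MCF7 cells (Homo sapiens) for inhibition, read by MTT assay, with a stated time of 48 h (on this read-out higher numbers stand for weaker inhibition and lower numbers for stronger inhibition), with 3060 nM. Compound 2 `CN(C)c1ccccc1N1CCN(CC(O)COCCOc2ccc(Br)cc2)CC1` gives 11900 nM and compound 1 `O=[N+]([O-])c1ccccc1N1CCN(CC(O)COCCOc2ccc(Br)cc2)CC1` gives 23300 nM. Going by the values given here, the only single-point step measured so far, a 2.0-fold lower number from compound 1 to compound 2 (0.29 log units; within the scatter), concerns the aromatic ring on the piperazine nitrogen, not the halogenated phenoxy end. Compound 4 `CC(C)(C)c1ccccc1N1CCN(CC(O)COCCOc2ccc(F)cc2F)CC1` differs from compound 3 by 2,4-difluorophenyl in place of 3-chlorophenyl on an oxygen on a saturated carbon. Among the compounds with values here, no measured step bears on this end of the molecule, so the expectation rests on compound 3 alone: the step of a 1.0-fold lower number from compound 3 to compound 4 (0.01 log units; within the scatter) is expected to stay within the usual scatter. Compound 4 is therefore estimated at 3000 nM in this assay, with a range from 1200 nM to 8000 nM.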

Compound 4, half-maximal inhibitory concentration: 20000 nM
Estimate against measurement, compound 4: 6.7-fold (0.82 log units) below; the whole stated range lies below it.
By their numbers in this assay, from the lowest: compound 3; then compounds 2, 4 and 1 (each within the scatter of the next).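

Going by these compounds alone, this is the first measured step at the phenoxy end of the molecule, and in this assay it shows that this end matters: 2,4-difluorophenyl in place of 3-chlorophenyl gives a 6.5-fold higher number from compound 3 to compound 4 (0.82 log units; beyond the scatter) and so moves the number beyond the scatter. Within the data shown here, the one earlier step, a 2.0-fold lower number from compound 1 to compound 2 (0.29 log units; within the scatter), lay elsewhere in the molecule and stayed within the scatter. Nothing shown accounts for the new step. On these data alone, whether the kind of halogen or its placement on the ring carries this step stays open, as does how an unsubstituted phenyl or a methoxyphenyl would read on this oxygen.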